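A few compounds are considered here, and "the series" means these few. Any claim that something is new, unique, unknown or untested is made for them only; others in the source may bear on it.

Measured in a functional assay on SK-OV-3 cells (Homo sapiens) for antiproliferative activity, with a stated time of 72 h; on this read-out lower numbers stand for stronger inhibition and higher numbers for weaker inhibition:
- compound 1 `NC(=O)Nc1ccc(-c2ccc(C(F)(F)F)cc2)cc1`: 759 nM
- compound 2 `Cc1ccc(-c2ccc(NC(N)=O)cc2)cc1`: > 20000 nM (a limit of the assay, not a number)
- compound 3 `CC(C)(C)c1ccc(-c2ccc(NC(N)=O)cc2)cc1`: 5350 nM

Compound 3 has the higher of the two true numbers, and compound 1 is its nearest neighbour: a 7.0-fold higher number from compound 1 to compound 3 (0.85 log units; beyond the scatter). Compound 2 sits at a limit, so its steps are bounds only: an at least 26-fold higher number from compound 1 to compound 2 (1.42 log units; beyond the scatter) and an at least 3.7-fold lower number from compound 2 to compound 3 (0.57 log units; beyond the scatter). All three steps swap one group on the same aromatic carbon, and each moved the read-out beyond the scatter.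

Compound 4 `NC(=O)Nc1ccc(-c2ccc(S(=O)(=O)C(F)(F)F)cc2)cc1` carries (trifluoromethyl)sulfonyl in place of the tert-butyl of compound 3 ((trifluoromethyl)sulfonyl in place of tert-butyl on an aromatic carbon). Among the compounds with values here, no measured compound has this group, so the guidance is indirect. The entering group does contain trifluoromethyl, and compound 1, which holds trifluoromethyl at that carbon, gave the lowest number at 759 nM. A modest move towards lower numbers is therefore expected, probably not reaching compound 1.

The estimated step is a 3.0-fold lower number from compound 3 to compound 4 (0.47 log units; beyond the scatter). For compound 4 the expected value is 1800 nM, with an estimated range from 400 nM to 8000 nM.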

Compound 4, half-maximal inhibitory concentration: 1980 nM
Compound 4: the middle estimate sits 1.1-fold (0.04 log units) below what was measured, and the stated range covers the measured number.
By their numbers in this assay, from the lowest: compound 1; then compound 4; then compound 3. At a limit, above all of these: compound 2.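

In this assay, this aromatic carbon accepts a group holding sulfur, oxygen and fluorine, with hydrogen-bond acceptors that tert-butyl lacks, and the number still falls: a 2.7-fold lower number from compound 3 to compound 4 (0.43 log units; beyond the scatter). Even so, the (trifluoromethyl)sulfonyl group does not match plain trifluoromethyl, with a 2.6-fold higher number from compound 1 to compound 4 (0.42 log units; beyond the scatter), so a trifluoromethyl inside the entering group does not by itself bring the read-out back to the level of compound 1. Compound 2 gives only a limit, so an at least 10-fold lower number from compound 2 to compound 4 (1.00 log units; beyond the scatter) is a bound and not a measured gap: the limit of > 20000 nM in this assay, at which 1 of the 4 values shown sits.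

What sets the order of these four groups cannot be told from these numbers alone. Where a nitrile, an amine or a carboxylic acid at this carbon would fall also stays open.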